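Furan to Thiophene on the Core of Compound 2

The compounds below may be only part of what the source reports. "The series", "measured", "known", "first", "only" and "open" are said of these compounds alone.

Three compounds built on the shared core of compound 1 `COC(=O)C1=C(C)N(C)C(=O)NC1c1ccoc1` have been tested in an assay on membranes from HeLa cells for displacement of a labelled ligand from adenosine receptor A3 (Homo sapiens), read by scintillation counting, with a stated time of 180 min, tested at 1 uM; a higher number here means more inhibition at the concentration tested (going by the name of the read-out), a lower number less inhibition. In that assay compound 1 gives 7%. Compound 2 `CCCOC(=O)C1=C(C)N(C)C(=O)NC1c1ccoc1` gives 16% in this assay, and compound 3 `CC1=C(C(=O)OCc2ccccc2)C(c2ccoc2)NC(=O)N1C` gives 25%. The two measured steps away from compound 1 alter only the ester: a number 9 percentage points higher from compound 1 to compound 2 (within the scatter), and a number 18 percentage points higher from compound 1 to compound 3 (beyond the scatter). Between the other two, a number 9 percentage points higher from compound 2 to compound 3 (within the scatter). Compound 2 thus sits second of the three numbers, with its nearer neighbour compound 1 and its farther neighbour compound 3 both within the scatter of it, so no order among compounds 1, 2 and 3 can be claimed beyond the modest rise from compound 1 to compound 3.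

Compound 4 `CCCOC(=O)C1=C(C)N(C)C(=O)NC1c1cccs1` keeps the propyl ester of compound 2 and changes the ring on the saturated ring carbon instead: thiophen-2-yl in place of furan-3-yl on a saturated ring carbon. Going by the values given here, none of the three measured steps touches that ring, so no measured step bears directly on this change. Since every change seen so far has stayed near or within the scatter, the expected step is a number 2 percentage points higher from compound 2 to compound 4 (within the scatter), that is, none beyond the scatter. Compound 4 is therefore estimated at 18% in this assay, with a range from 5% to 33%.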

Compound 4, a percentage reported as inhibition, at one concentration (the size of the read-out at that concentration, not a potency): 4%
Beside the measured number, compound 4's estimate is 14 percentage points above it; the measured number lies below the stated range.
By their numbers in this assay, from the lowest: compounds 4, 1, 2 and 3 (each within the scatter of the next, the first and the last beyond it).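

In this assay, going by these compounds alone, the exchange of furan-3-yl for thiophen-2-yl on the saturated ring carbon gives a number 12 percentage points lower from compound 2 to compound 4 (beyond the scatter), which shows that a change at this position, and not only in the ester, can move the number beyond the scatter; the only earlier step to do so, a number 18 percentage points higher from compound 1 to compound 3 (beyond the scatter), lies in the ester and runs the other way. The leaving and entering groups match in their counts of heavy atoms, hydrogen-bond donors and acceptors and carry no net charge, but they differ in two respects at once, sulfur in place of oxygen and the point of attachment, and this single step cannot separate the two. Nothing at hand accounts for the lower number.

The compounds shown leave open whether furan-2-yl or thiophen-3-yl at this position would tell the hetero atom apart from the point of attachment. They also leave open whether the same ring exchange would give a step of similar size on the methyl ester of compound 1 or the benzyl ester of compound 3, and how a plain phenyl ring would compare there.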